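Acetyl to Ethoxycarbonyl: A Step From a Limit

The compounds below may be only part of what the source reports. "The series", "measured", "known", "first", "only" and "open" are said of these compounds alone.

Measured in a functional assay on cells (Lymphocyte, Homo sapiens) for cytotoxicity; a lower number here means that less compound is tolerated, a higher number that more compound is tolerated:
Compound 1 `Cc1cc(C)cc(S(=O)(=O)c2c(C(=O)NNC(C)C)[nH]c3ccc(Cl)cc23)c1`: > 100 uM
Compound 2 `CC(=O)NNC(=O)c1[nH]c2ccc(Cl)cc2c1S(=O)(=O)c1cc(C)cc(C)c1`: > 100 uM

Both entries are limits, not numbers, so compound 2 has no exact standing: the limit of > 100 uM in this assay, at which 2 of the 2 values shown sit. Among the measured compounds shown here, the only measured step, acetyl in place of isopropyl on an amine nitrogen, is a step that the two limits leave unreadable from compound 1 to compound 2. It gives no size to carry forward. Compound 3 `CCOC(=O)NNC(=O)c1[nH]c2ccc(Cl)cc2c1S(=O)(=O)c1cc(C)cc(C)c1` carries ethoxy in place of methyl on a carbonyl carbon. With no readable step as a guide, no shift beyond the scatter is expected in this assay, in either direction. The estimated step is a number no higher from compound 2 to compound 3 (the limit leaves the size open). For compound 3 the expected value is 100 uM, with an estimated range from 40 uM to 200 uM.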

Compound 3, half-maximal toxic concentration: > 100 uM
Compound 3: a limit, no number; the forecaster's own chance of this, stated with the estimate: 80%; the middle value sits exactly at the limit.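

In this assay compound 1, compound 2 and compound 3 each give only a limit, not a number, so no new step can be read among them. The compounds shown leave open at what concentration any of the three becomes toxic, and whether these changes shift it at all.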